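The compounds below may be only part of what the source reports. "The series", "measured", "known", "first", "only" and "open" are said of these compounds alone.

Compound 1 `CCCCCCCC(=O)Nc1nc2ccc(NC(=O)c3c(Cl)cccc3Cl)cc2s1`: 0.18 ug/mL
Compound 2 `NCCC(=O)Nc1nc2ccc(NC(=O)c3c(Cl)cccc3Cl)cc2s1`: 5.3 ug/mL
Compound 3 `COCCOC(=O)Nc1nc2ccc(NC(=O)c3c(Cl)cccc3Cl)cc2s1`: 0.011 ug/mL

These three compounds share one core and differ only in the group carried by a nitrogen on an aromatic ring. In a functional assay on WI-38 VA13 cells (Homo sapiens) for cytotoxicity (on this read-out higher numbers stand for an effect only at larger amounts of compound and lower numbers for an effect already at smaller amounts), compound 3 gives the lowest number of the three; the steps of a 16-fold lower number from compound 1 to compound 3 (1.21 log units; beyond the scatter) and a 480-fold lower number from compound 2 to compound 3 (2.68 log units; beyond the scatter) both lie beyond the scatter, so compound 3 counts as the most potent of the three here. Compound 4 `COc1cccc(Nc2nc3ccc(NC(=O)c4c(Cl)cccc4Cl)cc3s2)c1` has not yet been measured. It differs from compound 3 in one place: 3-methoxyphenyl in place of (2-methoxyethoxy)carbonyl on a nitrogen on an aromatic ring. Every measured step kept a carbonyl on that nitrogen and changed only what hangs on it: a 29-fold higher number from compound 1 to compound 2 (1.47 log units; beyond the scatter) and a 16-fold lower number from compound 1 to compound 3 (1.21 log units; beyond the scatter). Among the compounds with values here, none of them swaps the whole (2-methoxyethoxy)carbonyl for an aromatic ring, so no measured step bears directly on this change; the measured steps show only that this position moves this assay over a wide span. Compound 3 gives 0.011 ug/mL, the lowest number seen, and the two other groups at this position gave higher numbers, so the expected step for compound 4 leans toward a higher number, with wide uncertainty. Compound 4 is expected to give about 0.1 ug/mL, between 0.01 ug/mL and 1.5 ug/mL. That estimate would mean a step of a 9.1-fold higher number from compound 3 to compound 4 (0.96 log units; beyond the scatter).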

Compound 4, half-maximal effective concentration: > 7.2 ug/mL
Compound 4: a limit, no number; the forecaster's own chance of this, stated with the estimate: 5%; middle value at least 72-fold (1.85 log units) from the limit.
By their numbers in this assay, from the lowest: compound 3; then compound 1; then compound 2. At a limit, above all of these: compound 4.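

Compound 4 stands at a limit of this assay, not at a number: the limit of > 7.2 ug/mL in this assay, at which 1 of the 4 values shown sits. The step of an at least 650-fold higher number from compound 3 to compound 4 (2.81 log units; beyond the scatter) and the step of an at least 40-fold higher number from compound 1 to compound 4 (1.60 log units; beyond the scatter) are the first shown that take the carbonyl off this nitrogen and put an aromatic ring there, and both are large, so this position is sensitive to more than the chain hanging on a carbonyl. The step of an at least 1.3-fold higher number from compound 2 to compound 4 (0.13 log units; that floor lies within the scatter) sets no order between those two compounds.

The compounds shown leave open whether the loss of the carbonyl or the arrival of the aromatic ring drives these steps, as the single change does both at once. A benzoyl group on this nitrogen would keep the carbonyl and bring in a ring, and a plain phenyl group would show what the methoxy adds.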